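The compounds below may be only part of what the source reports. "The series", "measured", "known", "first", "only" and "open" are said of these compounds alone.

Measured compounds in a functional assay on Vero cells (Chlorocebus sabaeus) for cytotoxicity; on this read-out lower numbers stand for higher toxicity in this test and higher numbers for lower toxicity in this test:
Compound 1 `CC(C)CCOC(=O)OCC(CO)CCn1cnc2cnc(N)nc21` gives 357000 nM.
Compound 2 `CCCCOC(=O)OCC(CO)CCn1cnc2cnc(N)nc21` gives > 500000 nM, which is a limit of this assay and not a number.

For the measured compounds named here, compound 2 thus stands only at a limit in this assay; the one measured step, an at least 1.4-fold higher number from compound 1 to compound 2 (0.14 log units; that floor lies within the scatter), rests on that limit (the limit of > 500000 nM in this assay, at which 1 of the 2 values shown sits). Compound 3 `CCOC(=O)OCC(CO)CCn1cnc2cnc(N)nc21` differs from compound 2 by hydrogen in place of ethyl on a saturated chain carbon, two bonds along the chain from an oxygen next to a carbonyl group. Going by the values given here, no measured step shortens the chain in this way, and the only step to hand points, if anywhere, towards higher numbers. Compound 3 is therefore expected to sit at or past the same limit, with the expected step that the limit leaves unreadable from compound 2 to compound 3; its estimate is 600000 nM, ranging from 300000 nM to 1500000 nM.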

Compound 3, half-maximal cytotoxic concentration: > 500000 nM
Compound 3: a limit, no number; the forecaster's own chance of this, stated with the estimate: 70%; the middle value does not contradict the limit.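

In this assay compound 3 gives > 500000 nM, which is a limit and not a number. For the compounds shown here, replacing butyl with the shorter ethoxy-bearing chain therefore still gives no number at this position, and the one readable comparison is an at least 1.4-fold higher number from compound 1 to compound 3 (0.14 log units; that floor lies within the scatter). The steps between the two limits cannot be read, so no trend with chain length can be drawn from butyl to ethyl: the limit of > 500000 nM in this assay, at which 2 of the 3 values shown sit.

From the compounds shown here alone, whether a longer chain such as hexyl, or an amine on the chain, would give a number in this assay remains open.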